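This account rests on a few compounds, and the source may have more. Where it says the series, first, only, none or still open, it means among the compounds named here.

Measured compounds in a functional assay on BCG823 cells (Homo sapiens) for inhibition, read by MTT assay, with a stated time of 72 h; on this read-out lower numbers stand for stronger inhibition and higher numbers for weaker inhibition:

compound 1 `CN(C(=O)NC(=O)c1ccc(Cl)cc1Cl)c1nc(C(F)(F)F)c(C(=O)N/N=C/c2cccc(C(F)(F)F)c2)s1`: 6.11 ug/mL
compound 2 `CN(C(=O)NC(=O)c1ccc(Cl)cc1Cl)c1nc(C(F)(F)F)c(C(=O)N/N=C/c2ccccc2C(F)(F)F)s1`: 5.73 ug/mL

Among the measured compounds shown here, compound 2 gives the lower of the two numbers, yet the one measured step, a 1.1-fold lower number from compound 1 to compound 2 (0.03 log units; within the scatter), is within the scatter, so the two compounds cannot be ranked against each other. Both carry the same core with the same acyl urea part; they differ only in the aryl group on the carbon with a double bond to nitrogen.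

Compound 3 `CN(C(=O)NC(=O)c1cccc([N+](=O)[O-])c1)c1nc(C(F)(F)F)c(C(=O)N/N=C/c2ccccc2C(F)(F)F)s1` is the next compound to be measured. Relative to compound 2 the change is 3-nitrophenyl in place of 2,4-dichlorophenyl on a carbonyl carbon. For the measured compounds named here, this touches the acyl urea side, which no measured step has varied: the step from compound 1 to compound 2 concerns a different place and does not bear on it. There is therefore no measured basis for a direction, and the expected step of a 1.0-fold higher number from compound 2 to compound 3 (0.02 log units; within the scatter) is none beyond the scatter, with a range widened to reflect the lack of a comparison. In this assay compound 3 is expected to give about 6 ug/mL, estimated between 2.5 ug/mL and 15 ug/mL.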

Compound 3, half-maximal inhibitory concentration: 3.97 ug/mL
For compound 3 the middle estimate is 1.5-fold (0.18 log units) above the measured one, and the stated range covers the measured number.
By their numbers in this assay, from the lowest: compounds 3, 2 and 1 (each within the scatter of the next).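

In this assay the acyl urea side now has a measured step of its own: a 1.4-fold lower number from compound 2 to compound 3 (0.16 log units; within the scatter) for 3-nitrophenyl in place of 2,4-dichlorophenyl on a carbonyl carbon whose other neighbour is an amide-type nitrogen. Within the scatter, this read-out does not separate the two aryl groups, even though the exchange removes both chlorine atoms and brings in a nitrogen and two oxygen atoms, so the position holds either group with no measurable consequence. No measurement at hand bears on the reason for this result.

Open at this carbonyl carbon is whether anything other than a substituted phenyl ring gives a comparable number, for example an amine, a carboxylic acid or a longer alkyl chain in place of the aryl group. Also open is whether the two sides of the molecule act independently: among the compounds shown, 3-nitrophenyl appears only with 2-(trifluoromethyl)phenyl on the carbon with a double bond to nitrogen, and its pairing with 3-(trifluoromethyl)phenyl remains unknown.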